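Trading ethoxy for hydroxy on a shared core

This account rests on a few compounds, and the source may have more. Where it says the series, first, only, none or still open, it means among the compounds named here.

Among the compounds with values here, in a functional assay on HCT-116 cells (Homo sapiens) for antiproliferative activity, read by CellTiter-Glo, with a stated time of 10 days (a higher number here means a weaker inhibitor, a lower number a stronger inhibitor), compound 1 `Cn1ncc(-c2cc(Cl)c3c(=O)[nH]nc(CN)c3c2)c1-c1sc2ccccc2c1C#N` gives 734 nM and compound 2 `CCOc1cc(-c2cnn(C)c2-c2sc3ccccc3c2C#N)cc2c(CN)n[nH]c(=O)c12` gives 637 nM, so compound 2 stands level with its only measured neighbour. Compound 3 `Cn1ncc(-c2cc(O)c3c(=O)[nH]nc(CN)c3c2)c1-c1sc2ccccc2c1C#N` has hydrogen in place of ethyl on an oxygen on an aromatic ring. Within the data shown here, the one measured swap nearby, ethoxy in place of chloro, is a 1.2-fold lower number from compound 1 to compound 2 (0.06 log units; within the scatter). That single small step gives no direction, so no change beyond the scatter is expected in this assay. The expected step is a 1.2-fold higher number from compound 2 to compound 3 (0.07 log units; within the scatter). Compound 3 is estimated at 750 nM, with an expected range of 250 nM to 2200 nM.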

Compound 3, half-maximal inhibitory concentration: 4350 nM
For compound 3 the middle estimate is 5.8-fold (0.76 log units) below the measured one; the measured number lies above the stated range.
By their numbers in this assay, from the lowest: compounds 2 and 1 (each within the scatter of the next); then compound 3.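

In this assay the group on this aromatic carbon does matter: replacing chloro with hydroxy gives a 5.9-fold higher number from compound 1 to compound 3 (0.77 log units; beyond the scatter) and removing the ethyl from the oxygen gives a 6.8-fold higher number from compound 2 to compound 3 (0.83 log units; beyond the scatter). Chloro and ethoxy read alike, so their earlier step within the scatter did not mean that any group fits here. No measurement on hand explains why hydroxy differs.

On these data alone, whether methoxy on this aromatic carbon would read like ethoxy or like hydroxy stays open. The same question stands for an amine there.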